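This account rests on a few compounds, and the source may have more. Where it says the series, first, only, none or still open, it means among the compounds named here.

In an ADME assay on a cell-free system (plasma, Homo sapiens) for metabolic stability, tested at 1 uM (a higher number here means that the compound lasts longer, a lower number that the compound disappears faster), two compounds have been measured so far. Compound 1 `C=CC(=O)N1CCN(S(=O)(=O)c2ccc(NC(=O)OCc3ccccc3)cc2)CC1` gives > 6 h, which is a limit of the assay and not a number. Compound 2 `C=CC(=O)NC1CCN(S(=O)(=O)c2ccc(C(=O)NCc3ccccc3)cc2)CC1` gives > 6 h, which is also a limit and not a number. The standing of compound 2 is therefore known only as a limit, and the whole picture so far is the limit of > 6 h in this assay, at which 2 of the 2 values shown sit.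

Compound 3 `C=CC(=O)NC1CCN(S(=O)(=O)c2ccc(C(=O)NCCC3CCCCC3)cc2)CC1` differs from compound 2 by having cyclohexylmethyl in place of phenyl on a saturated chain carbon bound to an amide-type nitrogen. Going by the values given here, no measured pair shows what such a change does here. The expected step is a number no higher from compound 2 to compound 3 (the limit leaves the size open), which means no shift beyond the usual scatter in either direction. For compound 3 the estimated half-life is 6 h, with an expected range from 3 h to 12 h, and the result may well be a limit again.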

Compound 3, half-life: > 6 h
Compound 3 gave a limit, no number; the forecaster's own chance of this, stated with the estimate: 70%; the middle value lies on the limit itself.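

Compound 2 and compound 3 each give a limit and not a number, so no step between them can be read in this assay: the limit of > 6 h in this assay, at which 3 of the 3 values shown sit.

Going by these compounds, what stays open is how long compound 1, compound 2 and compound 3 really last, and whether cyclohexylmethyl in place of phenyl changes that at all.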